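The compounds below may be only part of what the source reports. "The series", "measured", "known", "first", "only" and "open" are said of these compounds alone.

Compound 1 `O=C(Nc1ccc(C(F)(F)F)cc1)c1cc(Br)c(F)cc1O` and compound 2 `O=C(Nc1ccc(C(F)(F)F)cc1)c1cc(Br)ccc1O` share one core and differ in a single place. In a functional assay on KG-1 cells (Homo sapiens) for cytotoxicity, read by luminescence and CellTiter-Glo, with a stated time of 3 days (on this read-out higher numbers stand for weaker inhibition and lower numbers for stronger inhibition), compound 2 gives 610 nM, and compound 1 gives 820 nM. The change between them is fluoro in place of hydrogen on an aromatic carbon and it made a step of a 1.3-fold higher number from compound 2 to compound 1 (0.13 log units; within the scatter), so on this pair the change left the read-out essentially where it stood.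

Compound 3 `N#Cc1ccc(NC(=O)c2ccccc2O)cc1` has a different core, and the difference between its core and that of compound 2 is not broken down here. In this assay compound 3 gives 5370 nM, the highest of the three numbers, beyond the scatter from compound 1 and from compound 2.

Compound 4 `N#Cc1ccc(NC(=O)c2ccc(F)cc2O)cc1` has not yet been measured. It differs from compound 3 by fluoro in place of hydrogen on an aromatic carbon. Within the data shown here, this is the same kind of change as the one from compound 2 to compound 1, though not the same change: in compound 1 the entering fluoro sits ortho to a bromo group, meta to a hydroxy group and para to a large group, whereas in compound 4 it sits meta to a hydroxy group and para to a large group, and compound 4 carries no bromo group at all.

Because the same kind of change made only a step of a 1.3-fold higher number from compound 2 to compound 1 (0.13 log units; within the scatter), the expected step is a 1.1-fold higher number from compound 3 to compound 4 (0.05 log units; within the scatter), an expectation resting on that one measured pair and on nothing else. Compound 4 is accordingly estimated at 6000 nM, with a likely span from 2500 nM to 14000 nM.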

Compound 4, half-maximal inhibitory concentration: 3150 nM
Compound 4: the middle estimate sits 1.9-fold (0.28 log units) above what was measured; the measured number falls inside the stated range.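

In this assay, fluoro in place of hydrogen on an aromatic carbon made a step of a 1.7-fold lower number from compound 3 to compound 4 (0.23 log units; within the scatter), so on this second core, as on the first, the change left the read-out essentially where it stood. Set side by side, the two steps do not differ by more than repeated measurement would allow: the same change on two cores in this assay, a 1.3-fold higher number (0.13 log units; within the scatter) from compound 2 to compound 1 and a 1.7-fold lower number (0.23 log units; within the scatter) from compound 3 to compound 4, 2.3-fold (0.36 log units) apart, within the scatter of two such steps. Among these compounds, this shows that, on these two cores, the change carried over as a step too small to read, but it rests on only two pairs, in which the entering fluoro does not have the same surroundings, as compound 1 carries a bromo group and compound 4 has none, and it says nothing about any other core or any other place on the ring.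

The compounds shown leave open whether a chloro or a methoxy group at the place taken by fluoro in compound 4 would also leave the read-out where it stood. They also leave open how the read-out would respond if an amine or a carboxylic acid stood in place of the nitrile of compound 4.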